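This account rests on a few compounds, and the source may have more. Where it says the series, first, only, none or still open, it means among the compounds named here.

For the measured compounds named here, in an ADME assay on microsomes from liver (Rattus norvegicus) for pharmacokinetics (on this read-out lower numbers stand for slow clearance and higher numbers for fast clearance), compound 1 `Cn1cc(-c2ncc(C#N)c(N3C[C@@H]4C[C@H]3CN4CC3CC3)n2)cn1` gives 158 mL/min/kg, the higher of the two numbers so far, while compound 2 `C[C@@H]1C[C@H]1C(=O)N1CCN(c2nc(-c3cnn(C)c3)ncc2C#N)C[C@H]1C` gives 54 mL/min/kg, a gap beyond the scatter. Compound 3 `Cn1cc(-c2ncc(C#N)c(N3C[C@@H]4C[C@H]3CN4c3cccc(F)c3)n2)cn1` differs from compound 1 by 3-fluorophenyl in place of cyclopropylmethyl on an amine nitrogen in a ring, with 3-fluorophenyl in place of cyclopropylmethyl on an amine nitrogen in a ring. Going by the values given here, no measured pair isolates this change, so only a modest fall within the scatter is expected in this assay. The expected step is a 1.4-fold lower number from compound 1 to compound 3 (0.14 log units; within the scatter). For compound 3 the estimated value is 115 mL/min/kg, with an expected range of 55 mL/min/kg to 240 mL/min/kg.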

Compound 3, clearance: 1090 mL/min/kg
The estimate for compound 3 lay 9.5-fold (0.98 log units) below the measured number; the measured number lies above the stated range.
By their numbers in this assay, from the lowest: compound 2; then compound 1; then compound 3.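

In this assay, the amine nitrogen in a ring proves a strongly sensitive place on the core of compound 1: 3-fluorophenyl in place of cyclopropylmethyl gives a 6.9-fold higher number from compound 1 to compound 3 (0.84 log units; beyond the scatter) on this single change. For the compounds shown here, it is the first step that isolates one place, and it runs towards faster clearance. No available measurement explains the rise.

Going by these compounds, whether the rise follows the aromatic ring or its fluorine remains open, as does the effect of a plain phenyl or benzyl group at this nitrogen. This single step also cannot show whether the change would behave alike on another core.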